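The compounds below may be only part of what the source reports. "The series", "measured", "known", "first", "only" and "open" are said of these compounds alone.

Compound 3 `CC1=C(C(=O)SC(C)C)C(c2cccs2)NC(=O)N1` gives 1% in an assay on membranes from HEK293 cells for displacement of a labelled ligand from adenosine receptor A2b (Homo sapiens), read by scintillation counting, with a stated time of 30 min, tested at 1 uM; on this read-out lower numbers stand for less inhibition and higher numbers for more inhibition at the one concentration tested (going by the name of the read-out). Compound 2 `CCSC(=O)C1=C(C)NC(=O)NC1c1cccs1` gives 1%, and no change at the digits printed from compound 2 to compound 3 (within the scatter), so the two sit level, together the lowest of the three numbers measured. Compound 1 `CC1=C(C(=O)NC(C)C)C(c2cccs2)NC(=O)N1` gives 40%, and both thioesters fall well short of it: a number 39 percentage points lower from compound 1 to compound 2 (beyond the scatter) and a number 39 percentage points lower from compound 1 to compound 3 (beyond the scatter).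

Compound 4 `CC1=C(c2ncc(C)o2)C(c2cccs2)NC(=O)N1` has not yet been measured. It differs from compound 3 in one place: 5-methyl-1,3-oxazol-2-yl in place of (isopropylsulfanyl)carbonyl on a double-bonded ring carbon. Among the compounds with values here, none of the measured steps concerns this change. The two large steps only show that replacing the isopropylamino group on the carbonyl carbon with a sulfanyl group costs a great deal, while swapping one sulfanyl group for another changes nothing. On these data alone, whether an oxazole ring in place of the whole (isopropylsulfanyl)carbonyl group recovers any of what compound 1 shows is unknown, so the expectation rests on little. A small rise is expected, a number 14 percentage points higher from compound 3 to compound 4 (beyond the scatter), with wide uncertainty. Compound 4 is therefore estimated at 15%, within a range from 0% to 50%.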

Compound 4, a percentage reported as inhibition, at one concentration (the size of the read-out at that concentration, not a potency): 45%
Compound 4: middle estimate off by 30 percentage points, on the low side; measured number inside the range.
By their numbers in this assay, from the lowest: compounds 2 and 3 (each within the scatter of the next); then compounds 1 and 4 (each within the scatter of the next).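

In this assay, a carbonyl group on this double-bonded ring carbon is not required for a high reading: replacing the whole thioester with 5-methyl-1,3-oxazol-2-yl gives a number 44 percentage points higher from compound 3 to compound 4 (beyond the scatter) and a number 44 percentage points higher from compound 2 to compound 4 (beyond the scatter). The earlier steps shown here changed only the group on the carbonyl carbon, whereas this one shows that an aromatic ring can match the isopropylcarbamoyl group, with a number 5 percentage points higher from compound 1 to compound 4 (within the scatter). Nothing measured here explains why the ring and the amide read alike while the thioesters do not.

On these data alone, it remains open whether the methyl on the ring matters, and how a plain 1,3-oxazol-2-yl, a phenyl ring or a carboxylic acid would read at this place. These readings come from a single concentration, so they do not give the potency of compound 1 or compound 4.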